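Dropping the tert-Butyl Group from Compound 2

The source may report more compounds than this note shows. Statements on the series, on what has been measured and on what is new or still open speak of the compounds shown alone.

Compound 1 `CCN(c1nc(C)cc(C)n1)c1ccc(OC)cc1Br` gives 35 nM in an assay on isolated protein for binding affinity to corticotropin-releasing factor receptor 1 (Homo sapiens); a lower number here means a stronger inhibitor, a higher number a weaker inhibitor.
Compound 2 `CCN(c1nc(C)cc(C)n1)c1ccc(C(C)(C)C)cc1Br` gives only a limit, > 100 nM, in this assay.
Compound 3 `CCN(CC)c1cc(C)nc(N(CC)c2ccc(C(C)=O)cc2Br)n1` gives 5 nM in this assay.

Compound 2 thus stands at the weak end of the three, its value being a limit rather than a number (the limit of > 100 nM in this assay, at which 1 of the 3 values shown sits). Compound 4 `CCN(c1nc(C)cc(C)n1)c1ccccc1Br` differs from compound 2 by hydrogen in place of tert-butyl on an aromatic carbon. Among the measured compounds shown here, the one measured step that bears on this position is an at least 2.8-fold higher number from compound 1 to compound 2 (0.45 log units; beyond the scatter), so the tert-butyl group appears unfavourable, while a methoxy group gives a usable number. Taking the group away entirely is expected to fall between these cases, and the step of an at least 1.6-fold lower number from compound 2 to compound 4 (0.22 log units; that floor lies within the scatter) is estimated as a modest gain. Compound 4 is therefore expected to give 60 nM, within 20 nM to 300 nM.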

Compound 4, inhibition constant: > 1000 nM
Compound 4 ended at the assay's limit (the forecaster's own chance of this, stated with the estimate: 25%); middle value at least 16-fold (1.22 log units) from the limit.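

Taking the substituent away does not restore affinity: hydrogen in place of methoxy gives an at least 28-fold higher number from compound 1 to compound 4 (1.45 log units; beyond the scatter), so on this aromatic carbon the methoxy group is clearly better than no group at all. Compound 4 gives only a limit in this assay, not a number: the limit of > 1000 nM in this assay, at which 1 of the 4 values shown sits. Compound 2 also gives only a limit, so the step between these two cannot be read and tert-butyl and hydrogen cannot be ranked. Left open is how an amine, a hydroxy group or an ethoxy group on this carbon would compare with methoxy.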